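Amine swap at the chain end of the shared core

This account rests on a few compounds, and the source may have more. Where it says the series, first, only, none or still open, it means among the compounds named here.

Measured so far:
compound 1 `CCN(CC)CCCOc1cc2ncnc(Nc3ccc4sc(C(=O)Nc5c(C)cccc5Cl)cc4c3)c2cc1OC`: 4010 nM
compound 2 `COc1cc2c(Nc3ccc4sc(C(=O)Nc5c(C)cccc5Cl)cc4c3)ncnc2cc1OCCCN1CCCCC1`: 4340 nM

In a functional assay on U-937 cells (Homo sapiens) for cytotoxicity, read by MTT assay and WST assay, with a stated time of 72 h (on this read-out higher numbers stand for weaker inhibition and lower numbers for stronger inhibition), compound 2 gives 4340 nM, the higher of the two numbers, yet it sits within the scatter of compound 1, which gives 4010 nM. Compound 3 `COc1cc2c(Nc3ccc4sc(C(=O)Nc5c(C)cccc5Cl)cc4c3)ncnc2cc1OCCCN1CCN(C)CC1` carries 4-methylpiperazin-1-yl in place of piperidin-1-yl on a saturated chain carbon, three bonds along the chain from an oxygen on an aromatic ring, that is 4-methylpiperazin-1-yl in place of piperidin-1-yl on a saturated chain carbon, three bonds along the chain from an oxygen on an aromatic ring. For the measured compounds named here, the only step that bears on it is the earlier amine swap at the same place, a 1.1-fold higher number from compound 1 to compound 2 (0.03 log units; within the scatter), which stayed within the scatter. No step beyond the scatter is therefore expected here, in either direction, and the change is estimated to read as a 1.0-fold higher number from compound 2 to compound 3 (0.02 log units; within the scatter). Compound 3 is expected at 4500 nM, with a range from 2200 nM to 9500 nM.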

Compound 3, half-maximal inhibitory concentration: 3480 nM
Compound 3: middle estimate off by 1.3-fold (0.11 log units), on the high side; the measured number falls inside the stated range.
By their numbers in this assay, from the lowest: compounds 3, 1 and 2 (each within the scatter of the next).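

In this assay, the step to a ring with 2 hetero atoms at the chain end gives a 1.2-fold lower number from compound 2 to compound 3 (0.10 log units; within the scatter), and the comparison with the open-chain diethylamino end gives a 1.2-fold lower number from compound 1 to compound 3 (0.06 log units; within the scatter). The added ring nitrogen and its methyl group therefore leave the number within the scatter, so all three amine ends at this place read alike. No supporting data explain this flat result.

Going by these compounds, whether a morpholin-4-yl or carboxylic acid chain end would move the number beyond the scatter stays open. The same holds for a shorter or longer chain.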